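Carboxymethyl in Place of Fluoro on the Aryl Ring

The source may report more compounds than this note shows. Statements on the series, on what has been measured and on what is new or still open speak of the compounds shown alone.

Compound 1 `CC1CC/C(=N\Nc2cccc(C(=O)O)c2)c2nccc(=O)n21` does not reach a number in a functional assay on the whole organism for inhibition, with Rattus norvegicus as the target; on this read-out higher numbers stand for an effect only at larger amounts of compound and lower numbers for an effect already at smaller amounts; its result is the limit > 100 umol/kg. Among the compounds with values here, compound 2 `CC1CC/C(=N\Nc2ccc(F)cc2)c2ncc(C(=O)O)c(=O)n21` gives 12.2 umol/kg in this assay, the only number measured so far. Of the two values shown, the other is the limit of > 100 umol/kg in this assay, at which 1 of the 2 values shown sits, that of compound 1. Compound 3 `CC1CC/C(=N\Nc2ccc(CC(=O)O)cc2)c2ncc(C(=O)O)c(=O)n21` differs from compound 2 in one place: carboxymethyl in place of fluoro on an aromatic carbon. Within the data shown here, no measured pair shows a change of this kind, so the size of the step is open. Compound 3 is expected to show a step of a 2.5-fold higher number from compound 2 to compound 3 (0.39 log units; beyond the scatter) in this assay, toward an effect only at larger amounts. The estimate for compound 3 in this assay is 30 umol/kg, within 8 umol/kg to 120 umol/kg.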

Compound 3, dose for 50% inhibition: 60.9 umol/kg
For compound 3 the middle estimate is 2.0-fold (0.31 log units) below the measured one, and the stated range covers the measured number.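

At the aromatic carbon para to a large group, carboxymethyl in place of fluoro comes at a cost in this assay: a 5.0-fold higher number from compound 2 to compound 3 (0.70 log units; beyond the scatter). Within the data shown here, this is the first measured size for a change at this position, and compound 3 still gives a number rather than a limit. Compound 1 remains the one compound whose result is a limit: the limit of > 100 umol/kg in this assay, at which 1 of the 3 values shown sits.

Going by these compounds, whether the step follows from the chain or from its acid end stays open. A hydroxyethyl group, an aminomethyl group or a longer chain ending in a carboxylic acid at this carbon could separate the two.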